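The source may hold more compounds than are shown below. What is called first, only, known or untested is meant among the compounds shown, and "the series" means these compounds.

Measured compounds:
compound 1, `COc1cc2c(Oc3ccc(NC(=O)c4nn(-c5ccccc5OC(F)(F)F)c(=O)cc4C)cc3F)ccnc2cc1OCCCN1CCC(C)CC1`, 70 nM
compound 2, `COc1cc2c(Oc3ccc(NC(=O)c4nn(-c5cccc(F)c5)c(=O)cc4C)cc3F)ccnc2cc1OCCCN1CCCC1`, 120 nM
compound 3, `COc1cc2c(Oc3ccc(NC(=O)c4nn(-c5cccc(F)c5)c(=O)cc4C)cc3F)ccnc2cc1OCCCN1CCC(C)CC1`, 140 nM

All three were tested in a functional assay on MKN-45 cells (Homo sapiens) for inhibition, read by MTT assay, with a stated time of 72 h; a lower number here means a stronger inhibitor, a higher number a weaker inhibitor. Compound 3 has the highest of the three numbers, but its gaps to the others are small: compound 2 sits a 1.2-fold higher number from compound 2 to compound 3 (0.07 log units; within the scatter) away, and compound 1 a 2.0-fold higher number from compound 1 to compound 3 (0.30 log units; within the scatter) away, both within the usual scatter, so none of the three can be called apart from the others.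

Compound 4, `COc1cc2c(Oc3ccc(NC(=O)c4nn(-c5ccc(Cl)cc5Cl)c(=O)cc4C)cc3F)ccnc2cc1OCCCN1CCC(C)CC1`, has not yet been measured. It differs from compound 3 in one place: 2,4-dichlorophenyl in place of 3-fluorophenyl on an aromatic nitrogen. Within the data shown here, the one measured step that bears on this position is the change from compound 1 to compound 3, which gave only a 2.0-fold higher number from compound 1 to compound 3 (0.30 log units; within the scatter), within the scatter. Exchanging one substituted phenyl for another at this aromatic nitrogen therefore seems to move the number little, and no step beyond the scatter is expected here in this assay.

On that basis compound 4 is estimated at 100 nM, with a likely range from 40 nM to 250 nM. The expected step from compound 3 to compound 4 is a 1.4-fold lower number from compound 3 to compound 4 (0.15 log units; within the scatter).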

Compound 4, half-maximal inhibitory concentration: 120 nM
For compound 4 the middle estimate is 1.2-fold (0.08 log units) below the measured one; low and high end bracket the measured number.
By their numbers in this assay, from the lowest: compounds 1, 2, 4 and 3 (each within the scatter of the next).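

In this assay, a third substituted phenyl on this aromatic nitrogen, 2,4-dichlorophenyl, gives a 1.2-fold lower number from compound 3 to compound 4 (0.07 log units; within the scatter) when it replaces 3-fluorophenyl and a 1.7-fold higher number from compound 1 to compound 4 (0.23 log units; within the scatter) when it replaces 2-(trifluoromethoxy)phenyl. Among these compounds, earlier, only one pair of groups could be compared here; now three groups carrying fluorine, chlorine or trifluoromethoxy, all with the same 4-methylpiperidin-1-yl end, cannot be told apart. Nothing available explains why these groups give such similar numbers.

The compounds shown leave open whether a plain phenyl, a cyclohexyl, a small methyl or a phenyl carrying an amine or a carboxylic acid on this nitrogen would stay within this narrow band. They also leave open how 2,4-dichlorophenyl behaves when the chain ends in pyrrolidin-1-yl instead.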